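A few compounds are considered here, and "the series" means these few. Any claim that something is new, unique, unknown or untested is made for them only; others in the source may bear on it.

Compound 1 `O=c1[nH]c(=O)n(COCCO)cc1[N+](=O)[O-]` — > 400 ug/mL
Compound 2 `Nc1nc(Cl)c2ncn(COCCO)c2n1` — 50 ug/mL

Of the compounds shown here, two have so far been tested in a functional assay (Oryctolagus cuniculus) for inhibition; a lower number here means a stronger inhibitor, a higher number a weaker inhibitor. Compound 1 gives a limit of the assay rather than a number; its result is the limit of > 400 ug/mL in this assay, at which 1 of the 2 values shown sits. Within the data shown here, compound 2 gives the only real number in the set, 50 ug/mL, so it is the sole anchor against which any new compound can be compared. Among the measured compounds shown here, with just one limit and one number, no step between measured compounds can be drawn.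

Compound 3 `CC(=O)OCCOCn1cnc2c(Cl)nc(N)nc21` has not yet been measured. It is built from compound 2 by a single small change: acetyl in place of hydrogen on an oxygen on a saturated carbon. The core and the chain remain untouched, and the only difference is the acetyl group capping the oxygen that carried a hydrogen before.

A change of this kind at the far end of the chain is expected to move the result only modestly, if at all; the step of a 1.4-fold higher number from compound 2 to compound 3 (0.15 log units; within the scatter) from compound 2 to compound 3 is expected to stay close to the usual scatter, leaning slightly toward weaker inhibition. Compound 3 is therefore estimated to give 70 ug/mL, within a range from 25 ug/mL to 250 ug/mL.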

Compound 3, concentration for 50% inhibition: 55 ug/mL
Compound 3: the middle estimate sits 1.3-fold (0.10 log units) above what was measured; the range from low to high includes it.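

In this assay, putting acetoxy in place of hydroxy at the far end of the chain gives a 1.1-fold higher number from compound 2 to compound 3 (0.04 log units; within the scatter) and so leaves the two compounds indistinguishable. Among these compounds, this is the first step that can be read at this position, and it shows that inhibition at the level of compound 2 does not depend on keeping a free hydroxy at the end of the 2-hydroxyethyl part of the chain, at least for this one cap. The data shown hold no measurement that could explain this result.

Going by these compounds, one acetyl group is a narrow test of this position, so it remains open whether a methyl ether, a longer ester such as benzoyl, an amine or a carboxylic acid at the end of the chain would also leave the result unmoved, or whether one of them would shift it beyond the scatter. Among the compounds shown here, also open is how much a change to the shared core would matter, as the only readable step here leaves that core untouched.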